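Benzyl for 4-bromophenyl, carried over to a second core

The source may report more compounds than this note shows. Statements on the series, on what has been measured and on what is new or still open speak of the compounds shown alone.

Working notes on the series. Compound 1 `O=C(O)c1cn(C2CC2)c2cc(N3CCN(C(=O)CCSc4nnnn4-c4ccc(Br)cc4)CC3)c(F)cc2c1=O` carries 4-bromophenyl on the aromatic nitrogen; in a functional assay on SiHa cells (Homo sapiens) for inhibition, read by sulforhodamine B assay, with a stated time of 48 h (on this read-out lower numbers stand for stronger inhibition of growth and higher numbers for weaker inhibition of growth), compound 1 gives 60 nM. Compound 3 `CCn1cc(C(=O)O)c(=O)c2cnc(N3CCN(C(=O)CCSc4nnnn4-c4ccc(Br)cc4)CC3)nc21` carries the same side chain on another core, and in this assay compound 3 gives 60 nM. The difference between the two cores is not broken down here. Compound 2 `CCn1cc(C(=O)O)c(=O)c2cnc(N3CCN(C(=O)CCSc4nnnn4Cc4ccccc4)CC3)nc21` differs from compound 3 by benzyl in place of 4-bromophenyl on an aromatic nitrogen; in this assay compound 2 gives 60 nM, and the step reads no change at the digits printed from compound 3 to compound 2 (within the scatter). Compound 1 stands level with compound 2 and compound 3 at the digits shown, within the scatter either way.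

Compound 4 `O=C(O)c1cn(C2CC2)c2cc(N3CCN(C(=O)CCSc4nnnn4Cc4ccccc4)CC3)c(F)cc2c1=O` is the unmeasured counterpart of compound 1 under the same change, (benzyl in place of 4-bromophenyl on an aromatic nitrogen), at the same place. The change occurs twice among these compounds and has been measured once. The step expected is no change at the digits printed from compound 1 to compound 4 (within the scatter), resting on no change at the digits printed from compound 3 to compound 2 (within the scatter) and on no further evidence. Compound 4 is therefore estimated at 60 nM in this assay, with the expected range running from 30 nM to 120 nM.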

Compound 4, concentration for 50% growth inhibition: 60 nM
Beside the measured number, compound 4's estimate shows no gap at the digits printed; the measured number falls inside the stated range.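

In this assay the change reads no change at the digits printed from compound 1 to compound 4 (within the scatter), and set beside the earlier step it transfers from one core to the other without a detectable difference: the same change on two cores in this assay, no change at the digits printed (within the scatter) from compound 3 to compound 2 and no change at the digits printed (within the scatter) from compound 1 to compound 4, 1.0-fold (0.00 log units) apart, within the scatter of two such steps

For these two matched pairs, then, benzyl and 4-bromophenyl on the aromatic nitrogen cannot be told apart by this read-out, whichever of the two cores carries them. For the compounds shown here, this does not show that the change would stay silent on a third core or in another read-out, and with only two pairs, all at one level, it gives no reason for the agreement.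

Open, on these data alone, is whether a longer chain, such as 2-phenylethyl in place of benzyl, or an amine in place of the bromine on the phenyl ring, would keep the value level on both cores. Also open, as far as these compounds go, is whether the two cores would still agree once a change on the aromatic nitrogen produces a step beyond the scatter.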